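This account rests on a few compounds, and the source may have more. Where it says the series, first, only, none or still open, it means among the compounds named here.

Values so far in an ADME assay on BHK-21 cells (Mesocricetus auratus) for cytotoxicity, read by MTT assay, with a stated time of 72 h; a higher number here means that more compound is tolerated, a lower number that less compound is tolerated:

- compound 1 `NS(=O)(=O)c1ccc(N2N=C(c3ccc(OCc4ccccc4)cc3)CC2c2ccccc2Cl)cc1`: 12000 nM
- compound 2 `NS(=O)(=O)c1ccc(N2N=C(c3ccc(Oc4ccccc4)cc3)CC2c2cccc(F)c2)cc1`: 10000 nM

Only these two compounds have been measured in this assay. Compound 2 gives 10000 nM and compound 1 gives 12000 nM, so the two values lie within the scatter of each other, and neither can be set apart from the other. The next compound to be tested is compound 3 `NS(=O)(=O)c1ccc(N2N=C(c3ccc(Oc4ccccc4)cc3)CC2c2ccccc2Cl)cc1`. It differs from compound 2 at one place, with 2-chlorophenyl in place of 3-fluorophenyl on a saturated ring carbon. For the measured compounds named here, no measured pair of compounds differs in a single place, so the data give no direct measure of what this exchange does. Going by the values given here, the only guide is that compound 1, at 12000 nM, and compound 2, at 10000 nM, do not separate beyond the scatter. No clear direction is therefore expected, and the estimated change, a 1.1-fold higher number from compound 2 to compound 3 (0.04 log units; within the scatter), is expected to stay within the scatter. For compound 3 the expected value is 11000 nM, with an estimated range from 5000 nM to 25000 nM.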

Compound 3, half-maximal cytotoxic concentration: 8000 nM
Estimate against measurement, compound 3: 1.4-fold (0.14 log units) above, and the stated range covers the measured number.
By their numbers in this assay, from the lowest: compounds 3, 2 and 1 (each within the scatter of the next).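

In this assay the exchange of 3-fluorophenyl for 2-chlorophenyl on the saturated ring carbon now has a direct measure, a 1.3-fold lower number from compound 2 to compound 3 (0.10 log units; within the scatter), so compounds 2 and 3 cannot be set apart, although the halogen and its place on the phenyl ring differ between them. For the compounds shown here, compound 3 also gives the first direct reading of the group on the oxygen on the aromatic ring, with a 1.5-fold lower number from compound 1 to compound 3 (0.18 log units; within the scatter), and here too the two compounds cannot be set apart, so all three compounds lie close together and neither exchange has a direction that can be read. Nothing available explains these values or shows what lies behind them.

The compounds shown leave open whether the chlorine or its place on the phenyl ring matters on its own, since the two always change together here, and an unsubstituted phenyl, 2-fluorophenyl or 3-chlorophenyl at this carbon would separate those two. They also leave open whether something other than a halogen-bearing phenyl ring at this carbon, such as an amine or a carboxylic acid, would move the number beyond the scatter.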